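Moving from Methoxy to Allyloxy on a Shared Core

The source may hold more compounds than are shown below. What is called first, only, known or untested is meant among the compounds shown, and "the series" means these compounds.

Measured in a functional assay on HFF cells (Homo sapiens) for cytotoxicity; on this read-out lower numbers stand for higher toxicity in this test and higher numbers for lower toxicity in this test:
Compound 1 `CCCSc1nc(N)nc2c1ncn2/C=C1/C[C@@H]1CO`: 283000 nM
Compound 2 `COc1nc(N)nc2c1ncn2/C=C1/C[C@@H]1CO`: 15800 nM

Of these two, compound 2 stands lowest at 15800 nM, with compound 1 the nearest and only neighbour. Compound 3 `C=CCOc1nc(N)nc2c1ncn2/C=C1/C[C@@H]1CO` has not yet been measured. It changes methoxy to allyloxy, with vinyl in place of hydrogen on a saturated chain carbon bound to an oxygen on an aromatic ring. For the measured compounds named here, one measured step bears on this, though only indirectly: an 18-fold lower number from compound 1 to compound 2 (1.25 log units; beyond the scatter), a large step with methoxy in place of propylsulfanyl. That step also swaps the linking atom, so it suggests a direction rather than a size. The expected step is a 2.5-fold higher number from compound 2 to compound 3 (0.40 log units; beyond the scatter), moderate and towards a higher number in this assay. For compound 3 the estimated value is 40000 nM, with an expected range from 12000 nM to 130000 nM.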

Compound 3, half-maximal cytotoxic concentration: 220000 nM
For compound 3 the middle estimate is 5.5-fold (0.74 log units) below the measured one; the whole stated range lies below it.
By their numbers in this assay, from the lowest: compound 2; then compounds 3 and 1 (each within the scatter of the next).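

In this assay, the change from methoxy to allyloxy on this aromatic carbon gives a 14-fold higher number from compound 2 to compound 3 (1.14 log units; beyond the scatter) and so shows that the low number of compound 2 is not shared by every oxygen-linked group here. The earlier step changed the linking atom and the chain together, whereas a 1.3-fold lower number from compound 1 to compound 3 (0.11 log units; within the scatter) lies within the scatter and shows that an oxygen link can read like the sulfur link of compound 1 once allyloxy replaces methoxy. Nothing available explains why vinyl in place of hydrogen on this chain carbon has so large an effect.

Going by these compounds, it remains open whether the shift follows the double bond of allyloxy or simply the longer chain, a question that propoxy on the same carbon would address. On these data alone, how an amine at this carbon would read in this assay is also open.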